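Single-point binding notes: chloro removal on the sulfonyl aryl

The source may report more compounds than this note shows. Statements on the series, on what has been measured and on what is new or still open speak of the compounds shown alone.

Measured compounds:
- compound 1, `CC1CCN(c2c(S(=O)(=O)c3ccc(Cl)cc3)cnc3cc(Cl)ccc23)CC1`: 91%
- compound 2, `CC1CCN(c2c(S(=O)(=O)c3ccc(Cl)cc3)cnc3cc(F)ccc23)CC1`: 90%
- compound 3, `Cc1ccc(S(=O)(=O)c2cnc3ccc(F)cc3c2N2CCC(C)CC2)cc1Cl`: 91%

All three measured compounds were tested in an assay on isolated protein for displacement of a labelled ligand from metabotropic glutamate receptor 5 (Homo sapiens), with a stated time of 60 min, tested at 1 uM; a lower number here means less inhibition, a higher number more inhibition at the concentration tested (going by the name of the read-out). Compound 2 has the lowest of the three numbers, but its nearest neighbour, compound 1, sits only a number 1 percentage points lower from compound 1 to compound 2 (within the scatter) away, and compound 3 lies equally close, so the three values are indistinguishable within the scatter.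

The unmeasured compound 4, `CC1CCN(c2c(S(=O)(=O)c3ccccc3)cnc3cc(F)ccc23)CC1`, differs from compound 2 by hydrogen in place of chloro on an aromatic carbon. Read one bond further out, this is 4-chlorophenyl to phenyl on the sulfonyl side.

Going by the values given here, the only measured step, from compound 1 to compound 2, concerns a halogen swap on the shared core, not the sulfonyl aryl, and was a number 1 percentage points lower from compound 1 to compound 2 (within the scatter), within the scatter. Among the compounds with values here, no measured step addresses loss of the chloro on the sulfonyl aryl, so the expectation rests on the uniformly high values of compounds 1 to 3 with a wider allowance for a downward move. The step expected is a number 6 percentage points lower from compound 2 to compound 4 (within the scatter). For compound 4 the estimate in this assay is 84%, ranging from 65% to 95%.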

Compound 4, a percentage reported as inhibition, at one concentration (the size of the read-out at that concentration, not a potency): 87%
The estimate for compound 4 lay 3 percentage points below the measured number; the range from low to high includes it.
By their numbers in this assay, from the lowest: compounds 4, 2, 1 and 3 (each within the scatter of the next).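

In this assay, going by these compounds alone, the change from 4-chlorophenyl to phenyl gives a number 3 percentage points lower from compound 2 to compound 4 (within the scatter), the first reading at this position, as the earlier step concerned only a halogen on the shared core. At the one concentration tested, hydrogen in place of chloro on this aromatic carbon, para to a large group, produces no shift beyond the scatter, so the chloro is not required to retain the read-out in this pair. No data are available that bear on the reason for this outcome.

A single-concentration read-out does not show whether compound 2 and compound 4 differ in potency. Also open, as far as these compounds go, is how an amine, a carboxylic acid or a longer chain on this aromatic carbon would affect the read-out.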